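The source may report more compounds than this note shows. Statements on the series, on what has been measured and on what is new or still open speak of the compounds shown alone.

In a functional assay on the whole organism with Mus musculus as the target, in the maximal electroshock model, with a stated time of 120 min (on this read-out lower numbers stand for an effect already at smaller amounts and higher numbers for an effect only at larger amounts of compound), compound 1 `CCCc1cccc(N2CCNCC2)n1` gives 10 mg/kg. Compound 2 `CCCCCCc1cccc(N2CCNCC2)n1` in this assay gives 10 mg/kg, and the step of no change at the digits printed from compound 1 to compound 2 (within the scatter) shows no movement of the read-out. On these numbers compound 2 therefore stands level with compound 1, with nothing to separate them.

Compound 3 `CC(C)(C)c1cccc(N2CCNCC2)n1` differs from compound 2 by tert-butyl in place of hexyl on an aromatic carbon. Only one measured step bears on this change, no change at the digits printed from compound 1 to compound 2 (within the scatter), and it was flat; a swap to a branched group has no measured parallel among these compounds, so the comparison rests on one step alone. Given that single flat step, no step beyond the scatter is expected in this assay for compound 3, and the expected step is no change at the digits printed from compound 2 to compound 3 (within the scatter). Compound 3 is accordingly estimated at 10 mg/kg in this assay, within a range from 4 mg/kg to 25 mg/kg.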

Compound 3, minimum effective dose: > 300 mg/kg
Compound 3 ended at the assay's limit; the forecaster's own chance of this, stated with the estimate: 10%; middle value at least 30-fold (1.47 log units) away from the limit.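

Compound 3 gives > 300 mg/kg in this assay, and this is a limit of the assay, not a number: the limit of > 300 mg/kg in this assay, at which 1 of the 3 values shown sits. The earlier compounds shown here showed only that propyl and hexyl on this aromatic carbon, next to the ring nitrogen, sit level, yet tert-butyl at the same place brings an at least 30-fold higher number from compound 2 to compound 3 (1.47 log units; beyond the scatter), and in exchange for propyl it brings an at least 30-fold higher number from compound 1 to compound 3 (1.47 log units; beyond the scatter). Among these three compounds, the read-out at this position therefore stayed flat across the two straight chains but not with the branched tert-butyl group.

The three compounds leave open whether isopropyl or cyclopropyl at this place would follow the straight chains or tert-butyl. They also give no reason for the jump and do not show how an amine or a carboxylic acid would fare here.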